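Swapping Methoxy for Cyano on Two Related Cores

The source may hold more compounds than are shown below. What is called first, only, known or untested is meant among the compounds shown, and "the series" means these compounds.

Compound 1 `COc1cccc(-c2nc(N)c3nc(-c4ccccc4)sc3n2)c1` and compound 3 `COc1cccc(-c2nc(N)c3nc(-c4ccco4)sc3n2)c1` share most of their structure and differ only as described by furan-2-yl in place of phenyl on an aromatic carbon. In an assay on CHO cells for displacement of a labelled ligand from adenosine receptor A1 (Homo sapiens), read by scintillation counting, with a stated time of 3 h (a lower number here means a stronger inhibitor, a higher number a weaker inhibitor), compound 1 gives 176 nM, while compound 3 gives 62.3 nM, a shift of a 2.8-fold lower number from compound 1 to compound 3 (0.45 log units; beyond the scatter). Compound 2 `N#Cc1cccc(-c2nc(N)c3nc(-c4ccccc4)sc3n2)c1` differs from compound 1 by cyano in place of methoxy on an aromatic carbon; in this assay compound 2 gives 594 nM, so that change brought a 3.4-fold higher number from compound 1 to compound 2 (0.53 log units; beyond the scatter). Compound 4 `N#Cc1cccc(-c2nc(N)c3nc(-c4ccco4)sc3n2)c1` has not yet been measured. Within the data shown here, it differs from compound 3 by cyano in place of methoxy on an aromatic carbon, the same change at the same place as the one separating compound 1 from compound 2. Because a 3.4-fold higher number from compound 1 to compound 2 (0.53 log units; beyond the scatter) was seen on the first core, a similar weakening, a 3.4-fold higher number from compound 3 to compound 4 (0.53 log units; beyond the scatter), is expected on the second. Compound 4 is therefore estimated at 210 nM in this assay, probably between 100 nM and 450 nM.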

Compound 4, inhibition constant: 103 nM
For compound 4 the middle estimate is 2.0-fold (0.31 log units) above the measured one; the range from low to high includes it.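

In this assay, cyano in place of methoxy gives a 1.7-fold higher number from compound 3 to compound 4 (0.22 log units; within the scatter), and this step agrees with the same change on the other core: the same change on two cores in this assay, a 3.4-fold higher number (0.53 log units; beyond the scatter) from compound 1 to compound 2 and a 1.7-fold higher number (0.22 log units; within the scatter) from compound 3 to compound 4, 2.0-fold (0.31 log units) apart, within the scatter of two such steps. Furan-2-yl in place of phenyl gives a 5.8-fold lower number from compound 2 to compound 4 (0.76 log units; beyond the scatter), and this step also agrees with its earlier counterpart: the same change on two cores in this assay, a 2.8-fold lower number (0.45 log units; beyond the scatter) from compound 1 to compound 3 and a 5.8-fold lower number (0.76 log units; beyond the scatter) from compound 2 to compound 4, 2.0-fold (0.31 log units) apart, within the scatter of two such steps. Each change therefore carried over between the two cores within these four compounds, but this does not show that either would carry over to a further core or establish a general rule for the series.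

The compounds shown leave open what an amine or a carboxylic acid would do in place of the methoxy or cyano group. They also leave open what a longer chain would do there.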